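Fluoro for hydroxy on a chalcone-type scaffold

The source may hold more compounds than are shown below. What is called first, only, known or untested is meant among the compounds shown, and "the series" means these compounds.

Measured compounds in an assay on isolated protein for inhibition of DNA topoisomerase 1 (Homo sapiens), tested at 100 uM; a higher number here means a stronger effect of the compound at the concentration tested, a lower number a weaker effect:
- Compound 1, `COc1ccc(/C=C/C(=O)c2ccco2)cc1Br`: compound 1 gives 92%
- Compound 2, `COc1ccc(/C=C/C(=O)c2ccc(O)cc2)cc1Br`: compound 2 gives 24.8%
- Compound 3, `COc1ccc(C(=O)/C=C/c2ccc(OC)c(Br)c2)c(O)c1`: compound 3 gives 5%

Among these three numbers compound 2 stands second highest. Its nearest neighbour is compound 3, whose inhibition lies beyond the scatter below it, and the furthest is compound 1, whose inhibition lies beyond the scatter above it. No pair of these compounds differs in only one place, so no single step can be read from the measured set.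

Compound 4, `COc1ccc(/C=C/C(=O)c2ccc(F)cc2)cc1Br`, is not yet measured. It differs from compound 2 in one place: fluoro in place of hydroxy on an aromatic carbon. The hydroxy of compound 2 leaves and a fluoro enters at the same aromatic carbon, para to a large group, with the donor and acceptor of the hydroxy gone.

Among the compounds with values here, with no measured step of this kind to lean on, the expected change from compound 2 to compound 4 is small, in either direction, or none beyond the scatter; the estimated step is a number 5.2 percentage points higher from compound 2 to compound 4 (within the scatter). Compound 4 is therefore expected to give about 30%, within a range from 8% to 60%.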

Compound 4, a percentage reported as inhibition, at one concentration (the size of the read-out at that concentration, not a potency): 76.5%
Compound 4: the middle estimate sits 46.5 percentage points below what was measured, outside the stated range (above it).
By their numbers in this assay, from the lowest: compound 3; then compound 2; then compound 4; then compound 1.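

In this assay, within the data shown here, the aromatic carbon para to a large group proves to be a place where one small change counts: fluoro in place of hydroxy gives a number 51.7 percentage points higher from compound 2 to compound 4 (beyond the scatter), the first step in this set that can be read at a single place. The exchange removes the hydrogen-bond donor and acceptor of the hydroxy and brings in a fluoro with neither, yet this one step cannot show whether the gain comes from losing the hydroxy or from gaining the fluoro. Nothing available accounts for the size of this step.

An amine, a chloro or a carboxylic acid on the same carbon would help to separate those two readings. It also remains open whether this step would hold on the other cores shown, or whether the stronger effect seen at this one concentration would also appear at other concentrations.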